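A few compounds are considered here, and "the series" means these few. Any claim that something is new, unique, unknown or untested is made for them only; others in the source may bear on it.

Working notes on the series in an assay for binding affinity to Apoptosis regulator Bcl-2 (Homo sapiens), read by fluorescence polarization, with a stated time of 2 h; a higher number here means a weaker inhibitor, a lower number a stronger inhibitor. Within the data shown here, three analogues of the shared core have numbers so far. Compound 1 `Cc1c(C(=O)NCCCN2CCN(C)CC2)c(-c2cccc(N3CCN(c4ccc(NS(=O)(=O)c5cccc(S(=O)(=O)C6CC6)c5)cc4)CC3)c2)c(-c2ccc(Cl)cc2)n1C` gives 218 nM. Compound 2 `Cc1c(C(=O)NCCCN2CCN(C)CC2)c(-c2cccc(N3CCN(c4ccc(NS(=O)(=O)c5cccc(OC(F)(F)F)c5)cc4)CC3)c2)c(-c2ccc(Cl)cc2)n1C` gives 197 nM. Compound 3 `Cc1cccc(S(=O)(=O)Nc2ccc(N3CCN(c4cccc(-c5c(C(=O)NCCCN6CCN(C)CC6)c(C)n(C)c5-c5ccc(Cl)cc5)c4)CC3)cc2)c1` gives 178 nM, the lowest of the three numbers, although its steps to the other two are within the scatter: a 1.2-fold lower number from compound 1 to compound 3 (0.09 log units; within the scatter) and a 1.1-fold lower number from compound 2 to compound 3 (0.04 log units; within the scatter). Likewise a 1.1-fold lower number from compound 1 to compound 2 (0.04 log units; within the scatter) stays within the scatter. The unmeasured compound 4 `Cc1c(C(=O)NCCCN2CCN(C)CC2)c(-c2cccc(N3CCN(c4ccc(NS(=O)(=O)c5cccc(S(C)(=O)=O)c5)cc4)CC3)c2)c(-c2ccc(Cl)cc2)n1C` differs from compound 3 by methylsulfonyl in place of methyl on an aromatic carbon. The closest measured comparison is compound 1, whose cyclopropylsulfonyl group sits on the same aromatic carbon; that step to compound 3 was within the scatter, and so was the exchange for trifluoromethoxy in compound 2. Every change tried at this carbon has left this assay unmoved, so the step of a 1.1-fold higher number from compound 3 to compound 4 (0.05 log units; within the scatter) is expected to stay within the scatter as well. The number for compound 4 is expected near those of compound 1 and compound 3. Compound 4 is estimated at 200 nM, with a range from 100 nM to 400 nM.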

Compound 4, inhibition constant: 658 nM
Beside the measured number, compound 4's estimate is 3.3-fold (0.52 log units) below it; the whole stated range lies below it.
By their numbers in this assay, from the lowest: compounds 3, 2 and 1 (each within the scatter of the next); then compound 4.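

In this assay this aromatic carbon is not indifferent after all: methylsulfonyl brings a 3.7-fold higher number from compound 3 to compound 4 (0.57 log units; beyond the scatter) and a 3.3-fold higher number from compound 2 to compound 4 (0.52 log units; beyond the scatter) while methyl, trifluoromethoxy and cyclopropylsulfonyl had stayed within the scatter of each other. A sulfonyl group alone does not account for the shift, and compound 1 goes against such a reading: with the sulfonyl kept, methyl in place of cyclopropyl on the sulfur gives a 3.0-fold higher number from compound 1 to compound 4 (0.48 log units; beyond the scatter) and so ties the result to the group on the sulfur. No measurement at hand offers an explanation for this result.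

As far as these compounds go, whether ethyl or isopropyl on the same sulfur would track with methyl or with cyclopropyl stays open. Also open, from the compounds shown here alone, is how a sulfonamide or a carboxylic acid on this aromatic carbon would read in this assay.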